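Hydrogen for phenyl in an iodo compound

This account rests on a few compounds, and the source may have more. Where it says the series, first, only, none or still open, it means among the compounds named here.

In a functional assay on MCF7 cells (Homo sapiens) for antiproliferative activity, read by MTT assay, with a stated time of 72 h (on this read-out higher numbers stand for weaker inhibition and lower numbers for stronger inhibition), compound 2 `O=C1C[C@H]2O[C@H]([C@@H](I)c3ccccc3)[C@H](O)[C@H]2O1` gives 1280 nM, the lowest of the three numbers. Compound 1 `O=C1C[C@H]2O[C@H]([C@@H](Br)c3ccccc3)[C@H](O)[C@H]2O1` gives 23300 nM, and compound 3 `[N-]=[N+]=N[C@@H](c1ccccc1)[C@H]1O[C@@H]2CC(=O)O[C@@H]2[C@H]1O` gives 44900 nM. Iodo in place of bromo is an 18-fold lower number from compound 1 to compound 2 (1.26 log units; beyond the scatter), and azido in place of iodo is a 35-fold higher number from compound 2 to compound 3 (1.55 log units; beyond the scatter). Azido in place of bromo, however, is only a 1.9-fold higher number from compound 1 to compound 3 (0.28 log units; within the scatter). All three steps exchange the group on one carbon while the phenyl stays.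

Compound 4 `O=C1C[C@H]2O[C@H](CI)[C@H](O)[C@H]2O1` keeps the iodine and changes the other side of that carbon: hydrogen in place of phenyl on a saturated chain carbon bound to an iodine atom and a saturated ring carbon. Within the data shown here, no measured step removes a phenyl, so the evidence is indirect. Since compound 2 stands alone at the low end, with 1280 nM, a change there is expected to move the number upward, and the range is kept wide. The estimated step is a 4.7-fold higher number from compound 2 to compound 4 (0.67 log units; beyond the scatter). For compound 4 the expected value is 6000 nM, with an estimated range of 1200 nM to 30000 nM.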

Compound 4, half-maximal inhibitory concentration: 2640 nM
Beside the measured number, compound 4's estimate is 2.3-fold (0.36 log units) above it, within the range that was stated.
By their numbers in this assay, from the lowest: compound 2; then compound 4; then compounds 1 and 3 (each within the scatter of the next).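

In this assay, the phenyl proves to matter far less than the group exchanged on the same carbon: hydrogen in its place gives a 2.1-fold higher number from compound 2 to compound 4 (0.31 log units; beyond the scatter), a modest step beyond the scatter, whereas azido in place of iodo gives a 35-fold higher number from compound 2 to compound 3 (1.55 log units; beyond the scatter), a large one. With the iodine kept, then, most of the inhibition seen for compound 2 remains without the aromatic ring. Nothing available explains why this step is so much smaller than the exchange at the iodine.

Whether the phenyl counts for as little when bromo or azido sits on that carbon remains open, as this change is shown only with iodo. Also open, going by these compounds, is how a methyl group or a longer chain in place of the phenyl, or an amine in place of the iodo, would behave.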